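Shortening the Alkyne Chain and Expected Cell Tolerance

A few compounds are considered here, and "the series" means these few. Any claim that something is new, unique, unknown or untested is made for them only; others in the source may bear on it.

Compound 1 `CCCCCCC#Cc1cc2cn(COCCO)c(=O)nc2o1` carries a long alkyne chain on its core. In a functional assay on HEL cells (Homo sapiens), read by microscopy (a lower number here means that less compound is tolerated, a higher number that more compound is tolerated), compound 1 reaches only a limit of the assay, > 200000 nM, so its true value is not known. Compound 2 `CCCCCCCc1cc2cn(COCCO)c(O)nc-2n1`, a related structure with a saturated chain, likewise gives only a limit in this assay, >= 400000 nM. The two measured compounds thus sit at the limit of > 200000 nM in this assay, at which 1 of the 2 values shown sits, and at the limit of >= 400000 nM in this assay, at which 1 of the 2 values shown sits, and neither shows a measurable minimum cytotoxic concentration within the tested range.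

Compound 3 `CCCCC#Cc1cc2cn(COCCO)c(=O)nc2o1` differs from compound 1 by hydrogen in place of ethyl on a saturated chain carbon, four bonds along the chain from a triple-bonded carbon. Among the measured compounds shown here, no step between measured compounds is available to guide the size of this change. With nothing to draw on beyond the two limits, the change is expected to move the reading by no more than the scatter, a number no higher from compound 1 to compound 3 (the limit leaves the size open). The minimum cytotoxic concentration of compound 3 in this assay is expected to be around 200000 nM, within a range from 100000 nM to 400000 nM, and most likely reported once more as a limit rather than a number.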

Compound 3, minimum cytotoxic concentration: > 100000 nM
Compound 3: only a limit was reported (the forecaster's own chance of this, stated with the estimate: 85%); the middle value is on the limit's open side.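

Compound 1 and compound 3 both reach only a limit in this assay, and the step between them cannot be read. The compounds shown leave open the true minimum cytotoxic concentration of each, and whether the shorter alkyne chain changes cell tolerance at all.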